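Removing a Chloro Group from Two Related Cores

The compounds below may be only part of what the source reports. "The series", "measured", "known", "first", "only" and "open" are said of these compounds alone.

Compound 1 `O=C1COc2ccc(-c3cccc(NS(=O)(=O)c4ccc(F)cc4)c3)cc2N1c1ccc(Cl)cc1` and compound 2 `O=C1COc2ccc(-c3cccc(NS(=O)(=O)c4ccc(F)cc4)c3)cc2N1c1ccccc1` share one core, while compound 3 `O=C1COc2ccc(-c3cnc(Cl)c(NS(=O)(=O)c4ccc(F)cc4)c3)cc2N1c1ccc(Cl)cc1` and compound 4 `O=C1COc2ccc(-c3cnc(Cl)c(NS(=O)(=O)c4ccc(F)cc4)c3)cc2N1c1ccccc1` share another; the difference between the two cores is not broken down here. In a functional assay on HCT-116 cells (Homo sapiens) for antiproliferative activity, read by MTT assay, with a stated time of 72 h (on this read-out higher numbers stand for weaker inhibition and lower numbers for stronger inhibition), compound 1 gives 23900 nM. For compound 2 the assay reports only a limit, > 40000 nM. The step of an at least 1.6-fold higher number from compound 1 to compound 2 (0.22 log units; that floor lies within the scatter) follows from hydrogen in place of chloro on an aromatic carbon, and its floor is set by the limit of > 40000 nM in this assay, at which 1 of the 3 values shown sits. In this assay compound 3 gives 27900 nM, which sits within the scatter of compound 1. Compound 4 carries the same change, (hydrogen in place of chloro on an aromatic carbon). Within the data shown here, from compound 3, the step of a 1.6-fold higher number from compound 3 to compound 4 (0.21 log units; within the scatter) is expected to match an at least 1.6-fold higher number from compound 1 to compound 2 (0.22 log units; that floor lies within the scatter) in size, the only measured example of this change. Compound 4 is therefore estimated at 45000 nM, between 25000 nM and 90000 nM, and may well return as a limit.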

Compound 4, half-maximal inhibitory concentration: 39800 nM
Compound 4: the middle estimate sits 1.1-fold (0.05 log units) above what was measured, and the stated range covers the measured number.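

In this assay, replacing 4-chlorophenyl with phenyl on the second core gives a 1.4-fold higher number from compound 3 to compound 4 (0.15 log units; within the scatter). Set beside the same change on the first core, the result reads: the same change on two cores in this assay, an at least 1.6-fold higher number (0.22 log units; that floor lies within the scatter) from compound 1 to compound 2 and a 1.4-fold higher number (0.15 log units; within the scatter) from compound 3 to compound 4; the limit leaves it open whether they differ. The two cores therefore give no sign that the change behaves differently from one to the other, but this does not prove that it carries over unchanged, because one of the two steps rests on a limit rather than a number: the limit of > 40000 nM in this assay, at which 1 of the 4 values shown sits.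

The compounds shown leave open whether another group in the place of the chloro, such as a methoxy group, an amine or a carboxylic acid, would give a step beyond the scatter. They also leave open how the change from 4-chlorophenyl to phenyl would read on a third core.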